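Dimethylamino in place of ethyl in compound 3

A few compounds are considered here, and "the series" means these few. Any claim that something is new, unique, unknown or untested is made for them only; others in the source may bear on it.

In a functional assay on Chorioallantoic membrane (Gallus gallus, strain Leghorn), read by microscopy, with a stated time of 40 h (on this read-out higher numbers stand for weaker inhibition and lower numbers for stronger inhibition), compound 1 (`COc1ccc(Nc2ncnc3occ(C)c23)cc1`) gives 445 nM, compound 2 (`COc1ccc(N(c2ncnc3occ(C)c23)C(C)C)cc1`) gives 480 nM and compound 3 (`CCc1ccc(N(C)c2ncnc3occ(C)c23)cc1`) gives 287 nM, three numbers within the scatter of one another. Compound 4 (`Cc1coc2ncnc(N(C)c3ccc(N(C)C)cc3)c12`) carries dimethylamino in place of ethyl on an aromatic carbon. Going by the values given here, no measured step changes only this carbon. Among the compounds with values here, the one measured step, a 1.1-fold higher number from compound 1 to compound 2 (0.03 log units; within the scatter), is isopropyl in place of hydrogen on a nitrogen, so it bears only loosely, and it stays within the scatter. No shift beyond the scatter is therefore expected in this assay. The expected size is a 1.0-fold higher number from compound 3 to compound 4 (0.02 log units; within the scatter). Compound 4 is estimated at 300 nM, with an expected range from 120 nM to 750 nM.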

Compound 4, half-maximal inhibitory concentration: 653 nM
Compound 4: the middle estimate sits 2.2-fold (0.34 log units) below what was measured, within the range that was stated.
By their numbers in this assay, from the lowest: compounds 3, 1, 2 and 4 (each within the scatter of the next, the first and the last beyond it).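

In this assay dimethylamino in place of ethyl on an aromatic carbon, para to a large group, modestly weakens inhibition (a 2.3-fold higher number from compound 3 to compound 4 (0.36 log units; beyond the scatter)). This is the first step shown that lies beyond the scatter, so this carbon responds to the group it carries, which the one earlier step, made on a nitrogen, could not show. No available measurement bears on why the number moves here. Going by these compounds, whether a carboxylic acid or a longer chain such as propyl on this carbon would move the number further remains open.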